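A few compounds are considered here, and "the series" means these few. Any claim that something is new, unique, unknown or untested is made for them only; others in the source may bear on it.

In an ADME assay on microsomes from liver (Homo sapiens) for metabolic stability, read by LC-MS, with a stated time of 10 min (on this read-out lower numbers stand for a less stable compound and higher numbers for a more stable compound), three compounds sharing one core differ in the group on an amine nitrogen in a ring. Compound 1 `CN(C[C@H]1Cc2c(cccc2N2CCN(C3CC3)CC2)CN1)[C@H]1CCCc2cccnc21` gives 15.5%, compound 2 `CN(C[C@H]1Cc2c(cccc2N2CCN(Cc3ccccn3)CC2)CN1)[C@H]1CCCc2cccnc21` gives 4.2%, and compound 3 `CN(C[C@H]1Cc2c(cccc2N2CCN(c3cccc(C(F)(F)F)c3)CC2)CN1)[C@H]1CCCc2cccnc21` stands highest at 90.3%. Compound 4 `CN(C[C@H]1Cc2c(cccc2N2CCN(c3ncccn3)CC2)CN1)[C@H]1CCCc2cccnc21` carries pyrimidin-2-yl in place of 3-(trifluoromethyl)phenyl on an amine nitrogen in a ring. The relevant changes at this place are a number 74.8 percentage points higher from compound 1 to compound 3 (beyond the scatter) and a number 86.1 percentage points higher from compound 2 to compound 3 (beyond the scatter), both large, and a number 11.3 percentage points lower from compound 1 to compound 2 (beyond the scatter), which is modest. None of them tests pyrimidin-2-yl. For the measured compounds named here, the only high value, 90.3%, belongs to compound 3, so a fall of moderate to large size is expected, though the direction remains uncertain. The expected change is a number 35.3 percentage points lower from compound 3 to compound 4 (beyond the scatter). For compound 4, the estimated value is 55%, within an expected range of 20% to 90%.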

Compound 4, percent of the compound remaining: 35.5%
For compound 4 the middle estimate is 19.5 percentage points above the measured one, and the stated range covers the measured number.
By their numbers in this assay, from the lowest: compound 2; then compound 1; then compound 4; then compound 3.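

In this assay an aromatic ring on this nitrogen does not alone secure a high number, as pyrimidin-2-yl in place of 3-(trifluoromethyl)phenyl gives a number 54.8 percentage points lower from compound 3 to compound 4 (beyond the scatter) at this position. Pyrimidin-2-yl still ends clear of both earlier low groups, with a number 20 percentage points higher from compound 1 to compound 4 (beyond the scatter) and with a number 31.3 percentage points higher from compound 2 to compound 4 (beyond the scatter) in the same direction, so this position also allows an intermediate level. Nothing available accounts for these steps. Open, from the compounds shown here alone, is where an unsubstituted phenyl would stand, which would separate the share of the trifluoromethyl group from that of the carbon-only ring.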